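The source may report more compounds than this note shows. Statements on the series, on what has been measured and on what is new or still open speak of the compounds shown alone.

Values in an in vitro ADME assay on microsomes from liver (Simiiformes) (on this read-out lower numbers stand for a shorter-lived compound and higher numbers for a longer-lived compound), for the series:
- compound 1 `Cc1cc(CCCOc2c(C)cc(-c3noc(C)n3)cc2C)on1` gives 0.45 h as a number
- compound 2 `CCc1cc(CCCOc2c(C)cc(-c3noc(C(F)(F)F)n3)cc2C)on1` gives > 2.5 h as a limit
- compound 3 `Cc1cc(-c2noc(C(F)(F)F)n2)cc(C)c1OCCCc1cc(CO)no1` gives > 2.5 h as a limit

Compound 3 gives > 2.5 h in this assay as a limit and not a number. That position is the limit of > 2.5 h in this assay, at which 2 of the 3 values shown sit, and offers no numeric starting point. Compound 4 `Cc1ccc(CCCOc2c(C)cc(-c3noc(C(F)(F)F)n3)cc2C)cn1` carries 6-methylpyridin-3-yl in place of 3-(hydroxymethyl)-1,2-oxazol-5-yl (6-methylpyridin-3-yl in place of 3-(hydroxymethyl)-1,2-oxazol-5-yl on a saturated chain carbon, three bonds along the chain from an oxygen on an aromatic ring) on a saturated chain carbon, three bonds along the chain from an oxygen on an aromatic ring. Among the measured compounds shown here, the one measured step bearing on this (a step that the two limits leave unreadable from compound 2 to compound 3) has no readable size and sets no expected size. For the measured compounds named here, compound 1 gives 0.45 h as the sole number, so short half-lives do occur. A moderate shortening is expected (an at least 1.6-fold lower number from compound 3 to compound 4 (0.22 log units; that floor lies within the scatter)) with low confidence. For compound 4 the estimate is 1.5 h within an expected range of 0.5 h to 3.5 h and a limit reading remains possible.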

Compound 4, half-life: 1.97 h
For compound 4 the middle estimate is 1.3-fold (0.12 log units) below the measured one, and the stated range covers the measured number.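

In this assay, compound 4 shows that a group at this place, on a saturated chain carbon, three bonds along the chain from an oxygen on an aromatic ring, can give a number rather than a limit: the limit of > 2.5 h in this assay, at which 2 of the 4 values shown sit.

The change reads as an at least 1.2-fold lower number from compound 3 to compound 4 (0.10 log units; that floor lies within the scatter), and the change from 3-ethyl-1,2-oxazol-5-yl reads as an at least 1.2-fold lower number from compound 2 to compound 4 (0.10 log units; that floor lies within the scatter). Both floors lie within the scatter, so neither step is shown to exceed it.

As far as these compounds go, the true size of both steps stays open, and the step between compound 2 and compound 3 cannot be read. Also open, from the compounds shown here alone, is whether an amine or a carboxylic acid at this place gives a number in this assay.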